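The compounds below may be only part of what the source reports. "The series", "measured", "known", "first", "only" and "open" are said of these compounds alone.

Measured so far:
Compound 1 `CCCOC(=O)C1=C(C)NC(C)=C(C(=O)OC)C1c1cnc(SC)n1Nc1ccccc1` — in an assay on isolated protein (strain albino) for antagonist activity at Voltage-dependent L-type calcium channel subunit alpha-1C (Cavia porcellus) (on this read-out higher numbers stand for weaker inhibition and lower numbers for stronger inhibition), compound 1 gives 2.4 nM.
Compound 2 `COC(=O)C1=C(C)NC(C)=C(C(=O)OC(C)C)C1c1cnc(SC)n1Nc1ccccc1` — in this assay compound 2 gives 6.35 nM.

Among the compounds with values here, compound 2 stands at the higher of the two numbers seen in this assay; the only step leading to it is a 2.6-fold higher number from compound 1 to compound 2 (0.42 log units; beyond the scatter), a modest change beyond the scatter, brought about by a branched group in place of a straight chain on an oxygen next to a carbonyl group. Compound 3 `COCCOC(=O)C1=C(C)NC(C)=C(C(=O)OC)C1c1cnc(SC)n1Nc1ccccc1` differs from compound 2 by 2-methoxyethyl in place of isopropyl on an oxygen next to a carbonyl group. Within the data shown here, the single measured step, a 2.6-fold higher number from compound 1 to compound 2 (0.42 log units; beyond the scatter), is the only guide here: it shows that the choice of group on that oxygen shifts the number modestly, and that the straight propyl chain gave the lower number. The 2-methoxyethyl group is again a straight chain of comparable length, so the step from compound 2 is expected to run back in the lowering direction and to be of similar modest size, a 1.8-fold lower number from compound 2 to compound 3 (0.26 log units; within the scatter). Compound 3 is therefore estimated at 3.5 nM, with a range from 1.2 nM to 10 nM.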

Compound 3, half-maximal inhibitory concentration: 9.65 nM
The estimate for compound 3 lay 2.8-fold (0.44 log units) below the measured number; the measured number falls inside the stated range.
By their numbers in this assay, from the lowest: compound 1; then compounds 2 and 3 (each within the scatter of the next).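

In this assay, 2-methoxyethyl in place of isopropyl on the oxygen next to a carbonyl group gives a 1.5-fold higher number from compound 2 to compound 3 (0.18 log units; within the scatter), so at this position the branched isopropyl and the oxygen-bearing 2-methoxyethyl cannot be told apart, even though only 2-methoxyethyl has a hydrogen-bond acceptor. The comparison with the propyl ester is more informative: methoxy in place of methyl on the chain gives a 4.0-fold higher number from compound 1 to compound 3 (0.60 log units; beyond the scatter), which shows that an unbranched chain alone does not secure the lowest number, and compound 1 now stands apart from both other compounds by steps beyond the scatter. Nothing in hand accounts for why the propyl chain differs from the other two groups.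

The compounds shown leave open how a shorter ethyl group or a longer butyl chain on this oxygen would read, and so whether propyl marks a narrow optimum or just one point on a broader trend. They also leave open how a chain ending in a hydroxyl group or an amine would compare with the methoxy-ended chain of compound 3.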